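Combining Two Substituent Changes in a HeLa Antiproliferative Series

A few compounds are considered here, and "the series" means these few. Any claim that something is new, unique, unknown or untested is made for them only; others in the source may bear on it.

Three compounds have been measured in a functional assay on HeLa S3 cells (Homo sapiens) for antiproliferative activity, read by XTT assay, with a stated time of 72 h; on this read-out lower numbers stand for stronger inhibition and higher numbers for weaker inhibition:

compound 1 `CN(C)c1ncnc2c1c(-c1ccoc1)cn2[C@@H]1O[C@H](CO)[C@@H](O)[C@H]1O`: 9060 nM
compound 2 `CSc1ncnc2c1c(-c1ccoc1)cn2[C@@H]1O[C@H](CO)[C@@H](O)[C@H]1O`: 5390 nM
compound 3 `CSc1ncnc2c1c(-c1cccs1)cn2[C@@H]1O[C@H](CO)[C@@H](O)[C@H]1O`: 1960 nM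

Compound 2 and compound 1 share a core and differ by dimethylamino in place of methylsulfanyl on an aromatic carbon. This change gave a 1.7-fold higher number from compound 2 to compound 1 (0.23 log units; within the scatter). Compound 2 and compound 3 differ in their cores by thiophen-2-yl in place of furan-3-yl on an aromatic carbon, and that change gave a 2.8-fold lower number from compound 2 to compound 3 (0.44 log units; beyond the scatter). Compound 3 thus stands lowest of the three, with its steps to compound 2 and to compound 1 both beyond the scatter.

Compound 4 `CN(C)c1ncnc2c1c(-c1cccs1)cn2[C@@H]1O[C@H](CO)[C@@H](O)[C@H]1O` has not yet been measured. It differs from compound 3 by dimethylamino in place of methylsulfanyl on an aromatic carbon. The place of this change is described in the same words as for the pair of compound 2 and compound 1, so it is the same change made on the core of compound 3 rather than on the core of compound 2.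

The expectation for compound 4 rests on compound 1, where the step of a 1.7-fold higher number from compound 2 to compound 1 (0.23 log units; within the scatter) lay within the scatter. In this assay a step of about a 1.7-fold higher number from compound 3 to compound 4 (0.23 log units; within the scatter) is therefore expected. Compound 4 is estimated at 3300 nM, with a likely range from 1500 nM to 8000 nM.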

Compound 4, half-maximal inhibitory concentration: > 20000 nM
Compound 4 ended at the assay's limit (the forecaster's own chance of this, stated with the estimate: 2%); middle value at least 6.0-fold (0.78 log units) away from the limit.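

In this assay compound 4 gives > 20000 nM, which is a limit of the assay and not a number. Dimethylamino in place of methylsulfanyl gave an at least 10-fold higher number from compound 3 to compound 4 (1.00 log units; beyond the scatter), so the step seen with furan-3-yl in the molecule did not carry over to thiophen-2-yl: the same change on two cores in this assay, a 1.7-fold higher number (0.23 log units; within the scatter) from compound 2 to compound 1 and an at least 10-fold higher number (1.00 log units; beyond the scatter) from compound 3 to compound 4, at least 6.0-fold (0.78 log units) apart, beyond the scatter of two such steps The reverse reading agrees, for thiophen-2-yl in place of furan-3-yl gave an at least 2.2-fold higher number from compound 1 to compound 4 (0.34 log units; beyond the scatter), so the two changes do not act independently here, although these two pairs show neither the full size of the gap nor what lies behind it: the same change on two cores in this assay, a 2.8-fold lower number (0.44 log units; beyond the scatter) from compound 2 to compound 3 and an at least 2.2-fold higher number (0.34 log units; beyond the scatter) from compound 1 to compound 4, at least 6.0-fold (0.78 log units) apart, beyond the scatter of two such steps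

The compounds shown leave open whether this dependence extends to other groups in place of methylsulfanyl, such as a primary amine, a methylamino group or a longer alkylsulfanyl chain. They also leave open how either change would behave with other rings in place of thiophen-2-yl and furan-3-yl, such as phenyl or pyridine.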